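This account rests on a few compounds, and the source may have more. Where it says the series, first, only, none or still open, it means among the compounds named here.

Measured compounds:
- compound 1, `CCC(C)(C)Cc1c[nH]c(CCc2ccc(-n3ncnn3)cc2)n1`: 89 nM
- compound 2, `CCC(C)(C)Cc1c[nH]c(CCc2ccc(-n3cncn3)cc2)n1`: 89 nM

In a functional assay on HEK293 cells for agonist activity at Bombesin receptor subtype-3 (Homo sapiens), read by luminescence and calcium flux, with a stated time of 10 min (a lower number here means that less compound is needed, a higher number that more compound is needed for the effect), compound 2 gives 89 nM, and compound 1 gives 89 nM. Among the compounds with values here, compound 2 therefore stands level with compound 1; the only measured step, no change at the digits printed from compound 1 to compound 2 (within the scatter), exchanged one five-membered aromatic ring with three hetero atoms for another of the same kind and moved nothing beyond the scatter.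

Compound 3, `CCC(C)(C)Cc1c[nH]c(CCc2ccc(-c3cccnc3)cc2)n1`, departs from compound 2 by pyridin-3-yl in place of 1H-1,2,4-triazol-1-yl on an aromatic carbon. Within the data shown here, the single measured step bears on it only loosely: it shows that the ring at this position tolerated a swap between two closely related five-membered rings, but no measured step exchanges such a ring for a six-membered aromatic ring with one hetero atom, so the data do not tell how far the response depends on ring size. Given the tolerance seen, no shift beyond the scatter is expected, but the range around the estimate is kept wide. Compound 3 is expected to give 120 nM in this assay, between 35 nM and 450 nM, a step of a 1.3-fold higher number from compound 2 to compound 3 (0.13 log units; within the scatter).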

Compound 3, half-maximal effective concentration: 98 nM
Beside the measured number, compound 3's estimate is 1.2-fold (0.09 log units) above it; the measured number falls inside the stated range.
By their numbers in this assay, from the lowest: compounds 1, 2 and 3 (each within the scatter of the next).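

In this assay, the position on an aromatic carbon of a six-membered aromatic ring of carbon only, para to a large group, now also accepts a six-membered aromatic ring with 1 hetero atom: pyridin-3-yl in place of 1H-1,2,4-triazol-1-yl gives a 1.1-fold higher number from compound 2 to compound 3 (0.04 log units; within the scatter), and pyridin-3-yl in place of 2H-tetrazol-2-yl gives a 1.1-fold higher number from compound 1 to compound 3 (0.04 log units; within the scatter). The earlier compounds shown here showed tolerance only between two five-membered aromatic rings, whereas these steps change the ring size, the number of ring nitrogens and the hydrogen-bond acceptor count without any shift beyond the scatter, so across these three compounds the response does not follow any of those counts. Nothing measured alongside these numbers accounts for this tolerance.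

From the compounds shown here alone, it remains open whether a ring nitrogen is needed at all, which phenyl would test, and whether its place in the ring matters, which pyridin-2-yl and pyridin-4-yl would test. Going by these compounds, it is also open whether this tolerance extends beyond aromatic rings to a morpholine, a primary amine, a carboxylic acid or a longer alkyl chain at the same position.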